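A few compounds are considered here, and "the series" means these few. Any claim that something is new, unique, unknown or untested is made for them only; others in the source may bear on it.

Compound 1 `CCn1c(-c2cnc(C)nc2)nc2c(N[C@H]3CCN(C(=O)[C@H]4C[C@@H](OC)C4)C3)ncnc21`: in an ADME assay (Rattus norvegicus, strain Wistar Han) for pharmacokinetics (a lower number here means that more of the compound stays in the plasma, a higher number that more of the compound sits outside the plasma), compound 1 gives 4.1 L/kg.
Compound 2 `CCn1c(-c2cnc(C)nc2)nc2c(N[C@H]3CCN(C(=O)C4CC(F)(F)C4)C3)ncnc21`: in this assay compound 2 gives 18 L/kg.
Compound 3 `CCn1c(-c2cnc(C)nc2)nc2c(O[C@H]3CCN(C(=O)[C@H]4C[C@@H](OC)C4)C3)ncnc21`: in this assay compound 3 gives 2.5 L/kg.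

Compound 1 and compound 2 share one core; compound 3 and the still unmeasured compound 4 `CCn1c(-c2cnc(C)nc2)nc2c(O[C@H]3CCN(C(=O)C4CC(F)(F)C4)C3)ncnc21` share another. How the two cores differ is not broken down here. Within each pair the change is the same one: 3,3-difluorocyclobutyl in place of 3-methoxycyclobutyl on a carbonyl carbon in the first pair and 3,3-difluorocyclobutyl in place of 3-methoxycyclobutyl on a carbonyl carbon in the second, at the same place in both. Where this change has already been measured, it gave a 4.4-fold higher number from compound 1 to compound 2 (0.64 log units; beyond the scatter). Compound 3 and compound 1 give numbers that lie within the usual scatter of each other, while the number for compound 2 sits well beyond both. Carrying the one measured step over to the second core, compound 4 is expected to show a 4.4-fold higher number from compound 3 to compound 4 (0.64 log units; beyond the scatter), a step about as large as the earlier one, because the same change once gave a 4.4-fold higher number from compound 1 to compound 2 (0.64 log units; beyond the scatter). Compound 4 is therefore estimated at 11 L/kg, most likely between 5 L/kg and 25 L/kg.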

Compound 4, volume of distribution: 3 L/kg
Beside the measured number, compound 4's estimate is 3.7-fold (0.56 log units) above it, outside the stated range (below it).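

In this assay, putting 3,3-difluorocyclobutyl in place of 3-methoxycyclobutyl on the carbonyl carbon gives a 1.2-fold higher number from compound 3 to compound 4 (0.08 log units; within the scatter), so on this core the change makes no difference that can be told apart from ordinary repeat variation. The two cores therefore do not respond to this change by the same amount, and in this series its effect cannot simply be carried from one core to the other as a fixed step: the same change on two cores in this assay, a 4.4-fold higher number (0.64 log units; beyond the scatter) from compound 1 to compound 2 and a 1.2-fold higher number (0.08 log units; within the scatter) from compound 3 to compound 4, 3.7-fold (0.56 log units) apart, beyond the scatter of two such steps What this does not show is why the cores differ, or how any other change would carry over, as the comparison rests on just two matched pairs.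

The compounds shown leave open how other groups on the carbonyl carbon, such as a plain cyclobutyl or a 3-hydroxycyclobutyl, would behave on each core. They also leave open whether a further core would follow the large step of the first pair or the small step of the second.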